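Swapping Fluoro for Chloro at a Second Place

The compounds below may be only part of what the source reports. "The series", "measured", "known", "first", "only" and "open" are said of these compounds alone.

Measured so far in a functional assay on HT-29 cells (Homo sapiens) for cytotoxicity, read by MTT assay, with a stated time of 72 h; on this read-out higher numbers stand for weaker inhibition and lower numbers for stronger inhibition:
compound 1, `Cc1ccc2nc(NC(=O)c3cn(-c4ccccc4)nc3-c3ccc(F)cc3)sc2c1`: 22900 nM
compound 2, `Cc1ccc2nc(NC(=O)c3cn(-c4ccccc4)nc3-c3ccc(Cl)cc3)sc2c1`: 23700 nM
compound 3, `COc1ccc(-c2nn(-c3ccccc3)cc2C(=O)Nc2nc3ccc(F)cc3s2)cc1`: 5560 nM

Compound 3 gives the lowest number of the three, and its gap to compound 1 and to compound 2 lies beyond the scatter. How the core of compound 3 differs from the core of compound 1 is not broken down here.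

Compound 2 arises from compound 1 by chloro in place of fluoro on an aromatic carbon, and this gave a 1.0-fold higher number from compound 1 to compound 2 (0.01 log units; within the scatter). Compound 4, `COc1ccc(-c2nn(-c3ccccc3)cc2C(=O)Nc2nc3ccc(Cl)cc3s2)cc1`, arises from compound 3 by chloro in place of fluoro on an aromatic carbon. This is the same kind of change, but not the same: in compound 2 the place is para to a large group, whereas in compound 4 it is part of a fused or bridged system of two rings, meta to a fused ring and para to a fused ring.

Resting on the flat step from compound 1 to compound 2, compound 4 is expected to show a 1.1-fold higher number from compound 3 to compound 4 (0.03 log units; within the scatter) in this assay. Compound 4 is therefore estimated at 6000 nM, between 2500 nM and 14000 nM.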

Compound 4, half-maximal inhibitory concentration: 6570 nM
Compound 4: the middle estimate sits 1.1-fold (0.04 log units) below what was measured, within the range that was stated.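

Putting chloro in place of fluoro on the benzothiazole of compound 3 gave a 1.2-fold higher number from compound 3 to compound 4 (0.07 log units; within the scatter) in this assay. Set beside the earlier swap, the change reads the same on both cores: the same change on two cores in this assay, a 1.0-fold higher number (0.01 log units; within the scatter) from compound 1 to compound 2 and a 1.2-fold higher number (0.07 log units; within the scatter) from compound 3 to compound 4, 1.1-fold (0.06 log units) apart, within the scatter of two such steps. So in this assay the swap stayed within the scatter at two different places on two cores, but two pairs make no general rule, and they say nothing about other cores or other assays.

The compounds shown leave open whether a different group at this place, such as an amine or a carboxylic acid, would move the number beyond the scatter.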